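A Methyl Added to a Potent Sulfonamide

The source may hold more compounds than are shown below. What is called first, only, known or untested is meant among the compounds shown, and "the series" means these compounds.

Measured compounds:
Compound 1, `Cc1ccc(/N=C/c2ccccc2)cc1`, has "not determined" (no result reported) in a functional assay on LNCaP cells (Homo sapiens) for cytotoxicity, read by MTT assay, with a stated time of 5 days; on this read-out higher numbers stand for weaker inhibition of growth and lower numbers for stronger inhibition of growth.
Compound 2, `O=[N+]([O-])c1ccccc1NS(=O)(=O)c1ccccc1`, gives 14.8 nM in this assay.
Compound 3, `Cc1ccc(-c2nnn[nH]2)c(NS(=O)(=O)c2ccc(F)cc2)c1`, gives only a limit of this assay, > 100000 nM.

Among the three entries, compound 2 carries the only actual number in this assay; compound 3 stops at a limit rather than a value, and compound 1 has no result at all. Compound 3 sits at the limit of > 100000 nM in this assay, at which 1 of the 3 values shown sits.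

The unmeasured compound 4, `Cc1ccc(NS(=O)(=O)c2ccccc2)c([N+](=O)[O-])c1`, shares the sulfonamide and nitro groups of compound 2 and differs from it in one place: methyl in place of hydrogen on an aromatic carbon. The methyl enters on an aromatic carbon of the ring that bears the nitro group, meta to the nitro group and para to the large group.

For the measured compounds named here, no measured pair differing in one place is available, so the size of this step in this assay cannot be read from other compounds. A single methyl on an aromatic ring is the smallest kind of addition, and with nothing measured to suggest otherwise, the step from compound 2 to compound 4 is expected to stay within the usual scatter, in no settled direction.

Compound 4 is therefore estimated at 20 nM, with a range from 5 nM to 80 nM, an expected step of a 1.4-fold higher number from compound 2 to compound 4 (0.13 log units; within the scatter).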

Compound 4, concentration for 50% growth inhibition: 2.95 nM
Compound 4: middle estimate off by 6.8-fold (0.83 log units), on the high side; measured number below the stated range.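

In this assay, putting a methyl in place of hydrogen on this aromatic carbon, meta to the nitro group and para to the large group, is not a silent change: it gives a 5.0-fold lower number from compound 2 to compound 4 (0.70 log units; beyond the scatter). Since a lower number stands for stronger inhibition of growth, this carbon on the ring that bears the nitro group accepts one added carbon atom without any loss, and the inhibition of growth becomes stronger, a shift that a change this small need not have produced. Nothing in the measurements shown offers a reason for this step.

The compounds shown leave open whether a longer chain such as ethyl on the same carbon would push the number lower still or send it back up, and whether an amine or a chlorine atom there would act as the methyl does. They also leave open whether a methyl placed elsewhere on the shared core would give a step of similar size, as one pair speaks for this one position alone.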